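Removing a Chloro Group: Expected Stability of Compound 3

The source may report more compounds than this note shows. Statements on the series, on what has been measured and on what is new or still open speak of the compounds shown alone.

Compound 1 `N#Cc1cnc(NC(=O)CCCOc2cccc(Cl)c2)s1` was tested in an ADME assay on microsomes from liver (Mus musculus) for metabolic stability, read by LC-MS, using NADPH, tested at 1 uM (on this read-out higher numbers stand for a longer-lived compound and lower numbers for a shorter-lived compound), and gives 0.133 h. Compound 2 `Cc1cnc(NC(=O)CCCOc2cccc(C#N)c2)s1` gives 0.0667 h in this assay; the two numbers lie within the scatter of each other, so neither can be called the longer-lived. Compound 3 `N#Cc1cnc(NC(=O)CCCOc2ccccc2)s1` has not yet been measured. It differs from compound 1 by hydrogen in place of chloro on an aromatic carbon. Among the compounds with values here, since no measured pair shows this change, the step of a 1.2-fold lower number from compound 1 to compound 3 (0.08 log units; within the scatter) is expected to stay within the scatter, if anything slightly downward. Compound 3 is estimated at 0.11 h, with a range from 0.05 h to 0.25 h.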

Compound 3, half-life in the Mus musculus assay: 0.25 h
For compound 3 the middle estimate is 2.3-fold (0.36 log units) below the measured one, and the stated range covers the measured number.
By their numbers in the Mus musculus assay, from the lowest: compounds 2, 1 and 3 (each within the scatter of the next, the first and the last beyond it).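

In the Mus musculus assay, the first pair differing in one place gives a 1.9-fold higher number from compound 1 to compound 3 (0.27 log units; within the scatter), so hydrogen and chloro on this aromatic carbon show no difference in half-life beyond the scatter, while in a physicochemical assay for solubility, read by nephelometry, in phosphate buffer, at pH 6.5 (on this read-out lower numbers stand for lower solubility and higher numbers for higher solubility), compound 3 gives 1100 nM. In the physicochemical assay compound 1 gives < 1600 nM, which is a limit of the assay and not a number. The solubility step between these two compounds cannot be read because of this limit: the limit of < 1600 nM in the physicochemical assay, at which 1 of the 2 values shown sits.

As far as these compounds go, whether a methoxy group or an amine on this aromatic carbon would give a half-life beyond the scatter remains open.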